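Stereocentre inversion at the ring carbon of compound 2

The compounds below may be only part of what the source reports. "The series", "measured", "known", "first", "only" and "open" are said of these compounds alone.

Compound 2 `CCCCCCCC/C=C\CCCCCCCC(=O)O[C@H]1C=CCO[C@@H]1COP(=O)(O)OC[C@H](N)C(=O)O` is reported in an assay on HEK293-A cells for agonist activity at putative P2Y purinoceptor 10 (Mus musculus), with a stated time of 1.5 h (on this read-out lower numbers stand for smaller maximal responses and higher numbers for larger maximal responses), as "not active" (no number reported), with no single number given; the same holds for compound 1 `N[C@@H](COP(=O)(O)OC[C@H]1OCC=C[C@H]1OC(=O)CCc1ccccc1OCc1cccc(Oc2ccccc2)c1)C(=O)O`, which in this assay is "not active" (no number reported). Within the data shown here, the only compound of the series with a number is compound 3 `CCCCCCCCCCCOc1ccccc1CCC(=O)OC[C@H]1OCC=C[C@@H]1OP(=O)(O)OC[C@H](N)C(=O)O`, which in this assay reaches 7.6%. Compound 4 `CCCCCCCC/C=C\CCCCCCCC(=O)O[C@@H]1C=CCO[C@@H]1COP(=O)(O)OC[C@H](N)C(=O)O` has not been measured. Its change from compound 2 is the two compounds have the same atoms and bonds; at least one stereo element is drawn with a configuration in one of them and without one in the other: 1 of 5 stereo elements differ; a stereocentre at a saturated ring carbon is drawn S in compound 2 and R in compound 4. Among the measured compounds shown here, no step between two measured compounds is available, so the size of this step cannot be gauged from data; a shift of no more than the usual scatter is expected, in no particular direction. Compound 4 is therefore estimated at 10%, within a range of 0% to 30%, with a real chance that only an inactive call is reported.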

Compound 4, largest response reached (Emax), in percent of the reference or control that the assay uses: "not active" (no number reported)
No number was reported for compound 4; no gap can be computed for the estimate.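

In this assay compound 2 gives "not active" (no number reported) and compound 4 gives "not active" (no number reported), so no step can be read between them. Going by these compounds, whether the ring stereocentre affects the response stays open, and no available evidence bears on this.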